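Thiophene carboxamide thioureas: a trifluoromethyl swap revisited

The source may report more compounds than this note shows. Statements on the series, on what has been measured and on what is new or still open speak of the compounds shown alone.

Measured compounds:
Compound 1, `NC(=O)c1c(NC(=O)c2ccccc2I)sc2c1CCN(C(=S)Nc1ccccc1Br)C2`, 18900 nM
Compound 2, `NC(=O)c1c(NC(=O)c2ccccc2I)sc2c1CCN(C(=S)Nc1ccccc1C(F)(F)F)C2`, 19700 nM
Compound 3, `Cc1ccccc1C(=O)Nc1sc2c(c1C(N)=O)CCN(C(=S)Nc1ccccc1Br)C2`, 45200 nM

In a functional assay on HL-60 cells (Homo sapiens) for antiproliferative activity, with a stated time of 24 h (on this read-out higher numbers stand for weaker inhibition and lower numbers for stronger inhibition), compound 1 gives 18900 nM. Compound 2 carries trifluoromethyl in place of bromo on an aromatic carbon and gives 19700 nM, a step of a 1.0-fold higher number from compound 1 to compound 2 (0.02 log units; within the scatter). Compound 3 differs from compound 1 in its core by methyl in place of iodo on an aromatic carbon, with a 2.4-fold higher number from compound 1 to compound 3 (0.38 log units; beyond the scatter), and it gives 45200 nM.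

Compound 4, `Cc1ccccc1C(=O)Nc1sc2c(c1C(N)=O)CCN(C(=S)Nc1ccccc1C(F)(F)F)C2`, is not yet measured. It differs from compound 3 by trifluoromethyl in place of bromo on an aromatic carbon, the same change as that from compound 1 to compound 2; the surroundings of the place are the same in words. Because a 1.0-fold higher number from compound 1 to compound 2 (0.02 log units; within the scatter) lay within the scatter, a step of a 1.0-fold higher number from compound 3 to compound 4 (0.01 log units; within the scatter) is expected here. On that basis compound 4 is estimated at 46000 nM in this assay, between 20000 nM and 105000 nM.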

Compound 4, half-maximal inhibitory concentration: 23200 nM
Compound 4: the middle estimate sits 2.0-fold (0.30 log units) above what was measured; the measured number falls inside the stated range.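

In this assay, trifluoromethyl in place of bromo on the core of compound 3 gives a 1.9-fold lower number from compound 3 to compound 4 (0.29 log units; within the scatter), and this step does not separate from its earlier counterpart: the same change on two cores in this assay, a 1.0-fold higher number (0.02 log units; within the scatter) from compound 1 to compound 2 and a 1.9-fold lower number (0.29 log units; within the scatter) from compound 3 to compound 4, 2.0-fold (0.31 log units) apart, within the scatter of two such steps. Methyl in place of iodo, read with trifluoromethyl present, gives a 1.2-fold higher number from compound 2 to compound 4 (0.07 log units; within the scatter), and this step likewise does not separate from its counterpart: the same change on two cores in this assay, a 2.4-fold higher number (0.38 log units; beyond the scatter) from compound 1 to compound 3 and a 1.2-fold higher number (0.07 log units; within the scatter) from compound 2 to compound 4, 2.0-fold (0.31 log units) apart, within the scatter of two such steps. Each change therefore carried between these two settings without a difference that exceeds the scatter, but two pairs of steps cannot show that the steps are identical or that they would hold on any other core.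

The compounds shown leave open how an amine or a carboxylic acid in place of bromo would behave. They also leave open whether a longer chain in place of iodo would follow the same course.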